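The source may report more compounds than this note shows. Statements on the series, on what has been measured and on what is new or still open speak of the compounds shown alone.

Measured in an ADME assay on L1210/0 cells (Mus musculus) for cytotoxicity, with a stated time of 48 h; a lower number here means a stronger inhibitor, a higher number a weaker inhibitor:
- Compound 1 `O=c1[nH]c(=O)n([C@H]2C[C@H](O)[C@@H](CO)O2)cc1C#CCCCO`: > 200000 nM, a limit.
- Compound 2 `C[S+]([O-])c1cn([C@H]2C[C@H](O)[C@@H](CO)O2)c(=O)[nH]c1=O`: > 200000 nM, a limit.
- Compound 3 `O=c1[nH]c(=O)n([C@H]2C[C@H](O)[C@@H](CO)O2)cc1C#Cc1ccccc1`: > 200000 nM, a limit.

Compound 3 has no number to its name, only the limit > 200000 nM. It therefore cannot be ranked against the other two compounds.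

The next compound is compound 4 `CCCC/C=C\c1cn([C@H]2C[C@H](O)[C@@H](CO)O2)c(=O)[nH]c1=O`. The difference is hex-1-en-1-yl in place of 2-phenylethynyl on an aromatic carbon.

The measured steps closest to this change are a step that the two limits leave unreadable from compound 1 to compound 3 and a step that the two limits leave unreadable from compound 2 to compound 3. Neither gives a size, and a step that the two limits leave unreadable from compound 1 to compound 2 gives none either. No step beyond the scatter is expected in this assay for compound 4, because compound 1, compound 2 and compound 3 all stand at the limit of > 200000 nM in this assay, at which 3 of the 3 values shown sit. The estimated step is a number no higher from compound 3 to compound 4 (the limit leaves the size open). A plain limit is the most likely report. For compound 4 the expected value is 200000 nM, with an estimated range of 100000 nM to 400000 nM.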

Compound 4, half-maximal inhibitory concentration: > 200000 nM
Compound 4 gave a limit, no number; the forecaster's own chance of this, stated with the estimate: 85%; the middle value sits exactly at the limit.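

No step can be read from compound 1, compound 2 or compound 3 to compound 4 in this assay, because all four stand at a limit: the limit of > 200000 nM in this assay, at which 4 of the 4 values shown sit.

The compounds shown leave open whether any group at this position on the shared core gives a measurable half-maximal inhibitory concentration.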